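The compounds below may be only part of what the source reports. "The series", "measured", "known", "first", "only" and "open" are said of these compounds alone.

In a physicochemical assay for solubility, using the shake flask method, in simulated intestinal fluid, measured as kinetic solubility, with a stated time of 20 h, at pH 6.5 (a higher number here means a more soluble compound, a lower number a less soluble compound), compound 3 `FC(F)(F)c1ccc(Nc2cc3[nH]c(-c4cccc(C(F)(F)F)c4)nc3cn2)nc1` gives >= 50000 nM, which is a limit of the assay and not a number. Compound 1 `Fc1ccc(-c2nc3cnc(Nc4ccccn4)cc3[nH]2)cc1F`, which carries 3,4-difluorophenyl, gives >= 50000 nM, again a limit. Compound 2 `Fc1ccc(Nc2cc3[nH]c(-c4cccc(C(F)(F)F)c4)nc3cn2)nc1` gives >= 50000 nM, also a limit. Compound 3 therefore has no numerical place in the series, as the whole set shows (the limit of >= 50000 nM in this assay, at which 3 of the 3 values shown sit). Compound 4 `Fc1ccc(-c2nc3cnc(Nc4ccc(C(F)(F)F)cn4)cc3[nH]2)cc1F` differs from compound 3 in one place, with 3,4-difluorophenyl in place of 3-(trifluoromethyl)phenyl on an aromatic carbon. Among the measured compounds shown here, the only measured single change, a step that the two limits leave unreadable from compound 2 to compound 3, concerns another group, and its size cannot be read, so no measured step sizes this change. With every value at the same limit (the limit of >= 50000 nM in this assay, at which 3 of the 3 values shown sit), no step beyond the scatter is expected in this assay, in either direction. The expected change is a number no higher from compound 3 to compound 4 (the limit leaves the size open). For compound 4 the estimated value is 50000 nM, with an expected range of 25000 nM to 100000 nM, and it may well be reported only as a limit.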

Compound 4, solubility: >= 50000 nM
Compound 4 ended at the assay's limit; the forecaster's own chance of this, stated with the estimate: 80%; the middle value sits exactly at the limit.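

No new step can be read: the comparisons of compound 4 with compound 3 and with compound 1 stay unreadable, because each compound sits at the same limit, not at a number: the limit of >= 50000 nM in this assay, at which 4 of the 4 values shown sit.
The compounds shown leave open how far any of them lies past that limit in this assay, and so whether any of these changes moves the read-out at all.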